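Thiophen-3-yl in place of pyridin-2-yl on a purine-type riboside

This account rests on a few compounds, and the source may have more. Where it says the series, first, only, none or still open, it means among the compounds named here.

Compounds measured so far:
compound 1 `OC[C@H]1OC(n2cnc3c(-c4cc[nH]c4)ncnc32)[C@H](O)[C@@H]1O`: 17500 nM
compound 2 `OC[C@H]1OC(n2cnc3c(-c4ccccn4)ncnc32)[C@H](O)[C@@H]1O`: 4300 nM
compound 3 `OC[C@H]1OC(n2cnc3c(-c4cc[nH]n4)ncnc32)[C@H](O)[C@@H]1O`: 19800 nM

In a functional assay on L1210 cells (Mus musculus) for inhibition (on this read-out higher numbers stand for weaker inhibition and lower numbers for stronger inhibition), compound 2 gives the lowest of the three numbers; its nearest neighbour is compound 1, and compound 3 stands furthest away. The unmeasured compound 4 `OC[C@H]1OC(n2cnc3c(-c4ccsc4)ncnc32)[C@H](O)[C@@H]1O` differs from compound 2 in one place: thiophen-3-yl in place of pyridin-2-yl on an aromatic carbon. Within the data shown here, two measured steps bear on this change, since both replace pyridin-2-yl by a five-membered ring or the reverse: a 4.1-fold lower number from compound 1 to compound 2 (0.61 log units; beyond the scatter) and a 4.6-fold higher number from compound 2 to compound 3 (0.66 log units; beyond the scatter). Both five-membered rings gave clearly higher numbers than the pyridin-2-yl compound, and the step between them, a 1.1-fold higher number from compound 1 to compound 3 (0.05 log units; within the scatter), shows no difference beyond the scatter. Thiophen-3-yl carries no hydrogen-bond donor, unlike 1H-pyrrol-3-yl and 1H-pyrazol-3-yl, so the measured steps are only a partial guide; nevertheless, moving away from pyridin-2-yl is expected to raise the number modestly. The estimated step is a 2.1-fold higher number from compound 2 to compound 4 (0.32 log units; beyond the scatter). Compound 4 is therefore expected to give about 9000 nM in this assay, with a range from 2500 nM to 35000 nM.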

Compound 4, half-maximal inhibitory concentration: 10800 nM
Beside the measured number, compound 4's estimate is 1.2-fold (0.08 log units) below it; the measured number falls inside the stated range.
By their numbers in this assay, from the lowest: compound 2; then compounds 4, 1 and 3 (each within the scatter of the next).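

In this assay, thiophen-3-yl in place of pyridin-2-yl gives a 2.5-fold higher number from compound 2 to compound 4 (0.40 log units; beyond the scatter), so a third five-membered aromatic ring falls on the same side of compound 2 as the other two. The hydrogen on the ring nitrogen of 1H-pyrazol-3-yl and 1H-pyrrol-3-yl makes no difference that can be read here: a 1.8-fold lower number from compound 3 to compound 4 (0.26 log units; within the scatter) and a 1.6-fold lower number from compound 1 to compound 4 (0.21 log units; within the scatter) both lie within the scatter, and among these four compounds only the pyridin-2-yl compound stands apart. No measurement at hand accounts for this separation.

The compounds shown leave open whether the lower number of compound 2 goes with the six-membered ring itself or with its ring nitrogen, which phenyl or pyridin-3-yl at this position would separate. They also leave open how an amine or a short alkyl chain on this aromatic carbon would compare.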